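Chloro in place of methoxy: expected binding

This account rests on a few compounds, and the source may have more. Where it says the series, first, only, none or still open, it means among the compounds named here.

Compound 1 `Cc1cccc(-c2n[nH]cc2N2CCCNCC2)c1` and compound 2 `COc1ccccc1-c1n[nH]cc1N1CCNCC1` were both run in an assay on isolated protein for binding affinity to 5-hydroxytryptamine receptor 4 (Homo sapiens); a higher number here means a weaker inhibitor, a lower number a stronger inhibitor. Compound 1 gives only the assay limit, > 10000 nM. Compound 2 likewise gives only the assay limit, > 10000 nM. Compound 2 thus stands together with compound 1 at the limit of > 10000 nM in this assay, at which 2 of the 2 values shown sit; no measured number exists anywhere in the series. Compound 3 `Clc1ccccc1-c1n[nH]cc1N1CCNCC1` carries chloro in place of methoxy on an aromatic carbon. Among the compounds with values here, no step between measured compounds is available to scale this change, so the expected step from compound 2 to compound 3 in this assay is a step that the limit leaves unreadable from compound 2 to compound 3, none beyond the scatter. Compound 3 is estimated at 15000 nM, with a range from 3000 nM to 60000 nM, most likely again reported only as a limit.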

Compound 3, inhibition constant: > 10000 nM
Compound 3: no number, only a limit (the forecaster's own chance of this, stated with the estimate: 80%); the middle value lies beyond the limit too.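

Compound 2 and compound 3 both give only an assay limit, so no step between them can be read: the limit of > 10000 nM in this assay, at which 3 of the 3 values shown sit.
The compounds shown leave open what affinity, if any, this series reaches and how chloro in place of methoxy alters it.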